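The source may hold more compounds than are shown below. What is called first, only, known or untested is meant among the compounds shown, and "the series" means these compounds.

Measured in a physicochemical assay for solubility, in phosphate buffer, with a stated time of 18 h; a lower number here means a less soluble compound, a higher number a more soluble compound:
Compound 1 `CSc1nc(C(C)(C)C)nc2nc(N)c(C#N)c(N)c12`: 14000 nM
Compound 2 `CC(C)(C)c1nc(CCCCCC#N)c2c(N)c(C#N)c(N)nc2n1`: 6000 nM
Compound 3 `Cc1c[nH]c(-c2nc(C(C)(C)C)nc3nc(N)c(C#N)c(N)c23)n1`: 5000 nM

Compound 3 stands clearly under compound 1, with a 2.8-fold lower number from compound 1 to compound 3 (0.45 log units; beyond the scatter). It cannot be told apart from compound 2, with a 1.2-fold lower number from compound 2 to compound 3 (0.08 log units; within the scatter). Compound 4 `CC(C)(C)c1nc(-c2ccn[nH]2)c2c(N)c(C#N)c(N)nc2n1`, not yet measured, carries 1H-pyrazol-5-yl in place of 4-methyl-1H-imidazol-2-yl on an aromatic carbon. Going by the values given here, no measured compound carries the entering group, so the evidence is indirect. Among the compounds with values here, replacing methylsulfanyl at this place gave only modest steps, a 2.3-fold lower number from compound 1 to compound 2 (0.37 log units; beyond the scatter) and the one to compound 3 already given. Exchanging the two very different groups of the other pair gave a 1.2-fold lower number from compound 2 to compound 3 (0.08 log units; within the scatter). On that basis, a swap of one five-membered aromatic ring for another is expected to produce no step beyond the scatter in this assay. The expected change is a 1.2-fold higher number from compound 3 to compound 4 (0.08 log units; within the scatter). For compound 4 the estimated value is 6000 nM, with an expected range of 2500 nM to 14000 nM.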

Compound 4, solubility: 13500 nM
For compound 4 the middle estimate is 2.3-fold (0.35 log units) below the measured one; low and high end bracket the measured number.
By their numbers in this assay, from the lowest: compounds 3 and 2 (each within the scatter of the next); then compounds 4 and 1 (each within the scatter of the next).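

In this assay, this position proves sensitive to an exchange between two five-membered aromatic rings with 2 hetero atoms, giving a step beyond the scatter (a 2.7-fold higher number from compound 3 to compound 4 (0.43 log units; beyond the scatter)). The 1H-pyrazol-5-yl group also separates from 5-cyanopentyl (a 2.3-fold higher number from compound 2 to compound 4 (0.35 log units; beyond the scatter)) but cannot be told apart from methylsulfanyl (a 1.0-fold lower number from compound 1 to compound 4 (0.02 log units; within the scatter)), so the four compounds now form two levels, compounds 3 and 2 on the lower and compounds 4 and 1 on the upper. Nothing measured here accounts for the difference between the two rings.

The compounds shown leave open whether the step follows the methyl group or the arrangement of the ring nitrogens, which an unsubstituted 1H-imidazol-2-yl or a methyl-bearing pyrazole would separate. They also leave open whether an amine or a carboxylic acid at this place would rise above the upper level.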